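The source may hold more compounds than are shown below. What is called first, only, known or untested is meant among the compounds shown, and "the series" means these compounds.

In a functional assay on A549 cells (Homo sapiens) for antiproliferative activity, read by MTT assay, with a stated time of 48 h (a higher number here means a weaker inhibitor, a lower number a stronger inhibitor), compound 1 (`O=C(CCCCCC(=O)Nc1ccc(O)c(C(=O)Nc2ccc(F)c(F)c2)c1)NO`) gives 70100 nM, while compound 2 (`O=C(CCCCCC(=O)Nc1ccc(O)c(C(=O)Nc2ccc(F)c(Cl)c2)c1)NO`) gives 21100 nM, the lower of the two numbers. Compound 3 (`O=C(CCCCCC(=O)Nc1ccc(O)c(C(=O)Nc2cccc(C(F)(F)F)c2)c1)NO`) has 3-(trifluoromethyl)phenyl in place of 3-chloro-4-fluorophenyl on an amide-type nitrogen. Within the data shown here, only one measured step bears on this change: a 3.3-fold lower number from compound 1 to compound 2 (0.52 log units; beyond the scatter), a modest change with chloro in place of fluoro on an aromatic carbon. That single step gives no firm direction, so no shift beyond the scatter is expected in this assay. The expected change is a 1.4-fold higher number from compound 2 to compound 3 (0.15 log units; within the scatter). The estimate for compound 3 is 30000 nM, within an expected range of 10000 nM to 90000 nM.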

Compound 3, half-maximal inhibitory concentration: 25700 nM
Beside the measured number, compound 3's estimate is 1.2-fold (0.07 log units) above it; the measured number falls inside the stated range.
By their numbers in this assay, from the lowest: compounds 2 and 3 (each within the scatter of the next); then compound 1.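

In this assay the step gives a 1.2-fold higher number from compound 2 to compound 3 (0.09 log units; within the scatter) when 3-(trifluoromethyl)phenyl replaces 3-chloro-4-fluorophenyl on the amide-type nitrogen, so these two different groups cannot be told apart here. The step of a 2.7-fold lower number from compound 1 to compound 3 (0.44 log units; beyond the scatter) shows that the lower number seen with compound 2 is not tied to chlorine, since compound 3 carries none, and compound 1 alone stands apart. Nothing available explains this result.

The compounds shown leave open how a nitrile or a methoxy group on this phenyl ring would read in this assay and whether an unsubstituted phenyl would stay with compound 2 and compound 3 or with compound 1.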